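The source may report more compounds than this note shows. Statements on the series, on what has been measured and on what is new or still open speak of the compounds shown alone.

Compound 1 (`N/C(=N\NC(=S)N1CCOCC1)c1ccccn1`): in a functional assay on HeLa cells (Homo sapiens) for cytotoxicity, read by MTT assay, with a stated time of 72 h, tested at 3 uM (a higher number here means more inhibition of growth at the concentration tested, a lower number less inhibition of growth), compound 1 gives 40%.
Compound 2 (`N/C(=N\NC(=S)N1CCSCC1)c1ccc(F)cn1`): in this assay compound 2 gives 62.9%.

Compound 2 stands highest of the two numbers; compound 1 lies beyond the scatter below it, and the two compounds differ in more than one place, so their pair tells only what the two values show. Compound 3 (`N/C(=N\NC(=S)N1CCOCC1)c1ccc(F)cn1`) is reached from compound 2 by morpholin-4-yl in place of thiomorpholin-4-yl on a thiocarbonyl carbon. Compound 1 carries the same morpholin-4-yl group and gives the lower value, so a downward step is expected from compound 2 to compound 3, of size a number 12.9 percentage points lower from compound 2 to compound 3 (beyond the scatter), though it may still stay within the scatter. For compound 3 the estimate in this assay is 50%, with a range from 35% to 65%.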

Compound 3, percent growth inhibition at one concentration: 59.7%
Compound 3: the middle estimate sits 9.7 percentage points below what was measured; low and high end bracket the measured number.
By their numbers in this assay, from the lowest: compound 1; then compounds 3 and 2 (each within the scatter of the next).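

In this assay, morpholin-4-yl in place of thiomorpholin-4-yl on a thiocarbonyl carbon gives a number 3.2 percentage points lower from compound 2 to compound 3 (within the scatter) and so does not separate the two rings at this place. Fluoro in place of hydrogen on an aromatic carbon gives a number 19.7 percentage points higher from compound 1 to compound 3 (beyond the scatter) and is the first single change here to lie beyond the scatter, whereas compound 1 and compound 2 differ in more than one place.

From the compounds shown here alone, whether a chloro group on that aromatic carbon, or an open-chain dimethylamino group on the thiocarbonyl carbon, would give a different number stays open. Nothing available here explains either step.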